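Methoxy-for-hydrogen step on a pyrazoline series

The source may hold more compounds than are shown below. What is called first, only, known or untested is meant among the compounds shown, and "the series" means these compounds.

Measured compounds:
compound 1 `CC(=O)N1N=C(c2cccc([N+](=O)[O-])c2)CC1c1ccccc1` — 8710 nM
compound 2 `COc1ccc(C2CC(c3cccc([N+](=O)[O-])c3)=NN2C(C)=O)cc1` — 7830 nM
compound 3 `COc1ccc(C2CC(c3ccco3)=NN2C(C)=O)cc1OC` — 12300 nM

Three compounds have been run in a functional assay on PC-3 cells (Homo sapiens) for cytotoxicity, read by sulforhodamine B assay, with a stated time of 48 h; on this read-out higher numbers stand for weaker inhibition and lower numbers for stronger inhibition. Compound 1 `CC(=O)N1N=C(c2cccc([N+](=O)[O-])c2)CC1c1ccccc1` gives 8710 nM in this assay, compound 2 `COc1ccc(C2CC(c3cccc([N+](=O)[O-])c3)=NN2C(C)=O)cc1` gives 7830 nM, and compound 3 `COc1ccc(C2CC(c3ccco3)=NN2C(C)=O)cc1OC` gives 12300 nM. Compounds 1 and 2 differ by methoxy in place of hydrogen on an aromatic carbon, and the step of a 1.1-fold lower number from compound 1 to compound 2 (0.05 log units; within the scatter) is small. Compound 3 differs from compound 1 in more than one place; the difference between the two cores is not broken down here, and the three values lie close together.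

Compound 4 `COc1cc(OC)c(C2CC(c3ccco3)=NN2C(C)=O)cc1OC` is not yet measured. It differs from compound 3 by methoxy in place of hydrogen on an aromatic carbon. For the measured compounds named here, this is the same kind of change as the one from compound 1 to compound 2, not the same: in compound 2 the entering methoxy stands para to a large group, whereas in compound 4 it stands ortho to a large group, meta to a methoxy group and para to a methoxy group.

Going by the values given here, the only measured instance of this kind of change, a 1.1-fold lower number from compound 1 to compound 2 (0.05 log units; within the scatter), stayed within the scatter. The expectation is that the step in this assay from compound 3 to compound 4 will likewise be small, about a 1.1-fold lower number from compound 3 to compound 4 (0.05 log units; within the scatter), because the step of a 1.1-fold lower number from compound 1 to compound 2 (0.05 log units; within the scatter) gave no clear shift. Compound 4 is therefore estimated at 11000 nM in this assay, with a range from 5500 nM to 22000 nM allowing for the different surroundings of the new methoxy group.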

Compound 4, half-maximal inhibitory concentration: 8980 nM
Beside the measured number, compound 4's estimate is 1.2-fold (0.09 log units) above it, and the stated range covers the measured number.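

In this assay, methoxy in place of hydrogen on an aromatic carbon gives a 1.4-fold lower number from compound 3 to compound 4 (0.14 log units; within the scatter), and set beside the earlier step, the change reads alike on both cores: the same change on two cores in this assay, a 1.1-fold lower number (0.05 log units; within the scatter) from compound 1 to compound 2 and a 1.4-fold lower number (0.14 log units; within the scatter) from compound 3 to compound 4, 1.2-fold (0.09 log units) apart, within the scatter of two such steps. Within this series, the result is therefore a consistent absence of any clear shift, not a gain or loss that carries from one core to the other, and the agreement between two steps that both stay within the scatter says little about the size of any real underlying difference. It does not show that the step stays small on other cores, and although the entering methoxy stands in different surroundings in compound 2 and compound 4, these two steps cannot separate any influence of those surroundings.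

Still open, from the compounds shown here alone, is whether a clearer shift would appear with a different group at these aromatic carbons, such as an amine, a carboxylic acid or a longer alkoxy chain in place of methoxy. For the compounds shown here, the contribution of each part of the cores also remains unresolved, since compound 1 and compound 3 differ in more than one place and no single-place step connects the two pairs.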